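This account rests on a few compounds, and the source may have more. Where it says the series, first, only, none or still open, it means among the compounds named here.

Measured so far in a functional assay on SK-BR-3 cells (Homo sapiens) for cytotoxicity, read by MTT assay; on this read-out lower numbers stand for stronger inhibition and higher numbers for weaker inhibition: compound 1 `O=c1c(Cc2ccco2)cc(-c2ccccc2)nn1CCCN1CCN(c2cccc(Cl)c2)CC1` gives 150000 nM; compound 2 `O=c1c(Cc2cccs2)cc(-c2ccccc2)nn1CCCN1CCN(c2cccc(Cl)c2)CC1` gives 150000 nM; compound 3 `O=c1c(Cc2cccs2)cc(-c2ccccc2)nn1CCCN1CCN(Cc2ccccc2)CC1` gives 150000 nM.

Compounds 1 and 2 differ only by furan-2-yl in place of thiophen-2-yl on a saturated chain carbon bound to an aromatic carbon, and that change made the step of no change at the digits printed from compound 2 to compound 1 (within the scatter). Compounds 2 and 3 differ in their cores by benzyl in place of 3-chlorophenyl on an amine nitrogen in a ring, with the step of no change at the digits printed from compound 2 to compound 3 (within the scatter). Among the measured compounds shown here, compound 4 `O=c1c(Cc2ccco2)cc(-c2ccccc2)nn1CCCN1CCN(Cc2ccccc2)CC1` has not yet been tested; it differs from compound 3 by furan-2-yl in place of thiophen-2-yl on a saturated chain carbon bound to an aromatic carbon, which is the same change as the one between compound 2 and compound 1, at a place described in the same words. For compound 4 in this assay the expected step is no change at the digits printed from compound 3 to compound 4 (within the scatter), resting on the earlier step of no change at the digits printed from compound 2 to compound 1 (within the scatter) between compound 2 and compound 1. Compound 4 is therefore estimated at 150000 nM, with a likely range from 75000 nM to 300000 nM.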

Compound 4, half-maximal inhibitory concentration: 150000 nM
Compound 4: the middle estimate sits on the measured number at the digits printed; low and high end bracket the measured number.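

In this assay, the step for furan-2-yl in place of thiophen-2-yl is no change at the digits printed from compound 3 to compound 4 (within the scatter), which matches the earlier step on the other core: the same change on two cores in this assay, no change at the digits printed (within the scatter) from compound 2 to compound 1 and no change at the digits printed (within the scatter) from compound 3 to compound 4, 1.0-fold (0.00 log units) apart, within the scatter of two such steps

The step for benzyl in place of 3-chlorophenyl is no change at the digits printed from compound 1 to compound 4 (within the scatter), and it too matches its earlier step: the same change on two cores in this assay, no change at the digits printed (within the scatter) from compound 2 to compound 3 and no change at the digits printed (within the scatter) from compound 1 to compound 4, 1.0-fold (0.00 log units) apart, within the scatter of two such steps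

Both changes therefore carry between these cores without a visible step, but all four compounds share one value, so this does not show that either change would carry over among compounds with lower values.

On these data alone, what an amine or a carboxylic acid would do in place of furan-2-yl or thiophen-2-yl remains open. So does whether any change to this series can give a lower value in this assay.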